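A few compounds are considered here, and "the series" means these few. Any claim that something is new, unique, unknown or untested is made for them only; others in the source may bear on it.

Compound 1 `Cc1cc(=O)c(O)c(C(=O)O)o1`: 27%
Compound 2 `Cc1occ(O)c(=O)c1C(=O)O`: 6%

Both were tested in an assay on isolated protein for inhibition of methionine aminopeptidase 2 (Homo sapiens), read by fluorescence, tested at 200 uM; a higher number here means more inhibition at the concentration tested (going by the name of the read-out), a lower number less inhibition. Compound 1 gives the higher of the two numbers, and compound 2 lies lower by an amount beyond the usual scatter. Compound 3 `O=C(O)c1occc(=O)c1O` has not yet been measured. It differs from compound 1 in a single place: hydrogen in place of methyl on an aromatic carbon. Going by the values given here, no measured pair shows what this change does here, so the expectation rests on compound 1 alone. Removing one carbon is a small change, and only a slight drop, or none beyond the scatter, is expected for the step of a number 7 percentage points lower from compound 1 to compound 3 (within the scatter). Compound 3 is accordingly estimated at 20%, within a range of 5% to 35%.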

Compound 3, a percentage reported as inhibition, at one concentration (the size of the read-out at that concentration, not a potency): 5%
Estimate against measurement, compound 3: 15 percentage points above; the range from low to high includes it.
By their numbers in this assay, from the lowest: compounds 3 and 2 (each within the scatter of the next); then compound 1.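

The methyl on the aromatic carbon next to the ring oxygen counts for more than its single carbon suggests: in this assay, hydrogen in its place gives a number 22 percentage points lower from compound 1 to compound 3 (beyond the scatter). At this position, then, the methyl is tied to the inhibition seen with compound 1, and even removing one carbon can matter. Nothing measured here explains this step. Still open, as far as these compounds go, is whether an ethyl group or a longer chain on the same carbon would raise the number further or lower it. An amine or a chlorine atom there is equally untested among these compounds.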